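The compounds below may be only part of what the source reports. "The series", "measured", "known", "first", "only" and "open" are said of these compounds alone.

Measured compounds:
compound 1, `CS(=O)(=O)c1ccc(C(=O)N2CCC(C(=O)N3CCc4ccccc43)CC2)cc1[N+](=O)[O-]`: > 60000 nM
compound 2, `Cc1ccc(N2CCN(C(=O)C3CCN(C(=O)c4ccc(S(C)(=O)=O)c([N+](=O)[O-])c4)CC3)CC2)cc1`: > 60000 nM

In an assay on isolated protein for inhibition of vitamin D3 receptor (Homo sapiens), read by fluorescence polarization (a lower number here means a stronger inhibitor, a higher number a weaker inhibitor), compound 1 gives > 60000 nM, which is a limit of the assay. Compound 2 likewise gives only a limit, > 60000 nM. Both values sit at the same place, (the limit of > 60000 nM in this assay, at which 2 of the 2 values shown sit), so compound 2 stands at the limit with no number to compare.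

Compound 3, `CN1CCN(C(=O)C2CCN(C(=O)c3ccc(S(C)(=O)=O)c([N+](=O)[O-])c3)CC2)CC1`, differs from compound 2 by methyl in place of 4-methylphenyl on an amine nitrogen in a ring. Within the data shown here, no step between measured compounds is available. Compound 3 is expected to remain at the limit, around 100000 nM, within 30000 nM to 400000 nM. The expected step is a step that the limit leaves unreadable from compound 2 to compound 3, none beyond the scatter.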

Compound 3, half-maximal inhibitory concentration: > 60000 nM
Compound 3: only a limit was reported; the forecaster's own chance of this, stated with the estimate: 90%; the middle value lies beyond the limit too.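

No step can be read in this assay between compound 3 and compound 1 or compound 2, since all three values are limits: the limit of > 60000 nM in this assay, at which 3 of the 3 values shown sit.

The compounds shown leave open which change to the shared core, if any, would give a measurable value in this assay.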